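Fluorophenyl for Methylphenyl on a Weakly Active Triazole

The source may hold more compounds than are shown below. What is called first, only, known or untested is meant among the compounds shown, and "the series" means these compounds.

Compound 1 `COc1cc(-n2ncnc2-c2ccc(C)cc2)cc(OC)c1OC` in a functional assay on K562 cells (Homo sapiens) for antiproliferative activity, read by MTT assay, with a stated time of 72 h (on this read-out higher numbers stand for weaker inhibition and lower numbers for stronger inhibition), gives > 10000 nM, which is a limit of the assay rather than a number.
Compound 2 `COc1cc(-c2ncnn2-c2ccc(N)cc2)cc(OC)c1OC` in this assay gives > 10000 nM, again a limit.
Compound 3 `COc1ccc(-n2ncnc2-c2cc(OC)c(OC)c(OC)c2)cc1` in this assay gives 3600 nM.

Compound 1 therefore stands at the limit of > 10000 nM in this assay, at which 2 of the 3 values shown sit, with no number of its own. Among the compounds with values here, the only measured step, an at least 2.7-fold lower number from compound 2 to compound 3 (0.44 log units; beyond the scatter), concerns methoxy in place of amino on an aromatic carbon and does not touch the part altered here. Compound 4 `COc1cc(-n2ncnc2-c2cccc(F)c2)cc(OC)c1OC` differs from compound 1 by 3-fluorophenyl in place of 4-methylphenyl on an aromatic carbon. Within the data shown here, no measured step bears on this change, so no shift beyond the scatter is expected, and compound 4 is expected to stay weak. Compound 4 is estimated at 10000 nM, within 3000 nM to 30000 nM, which corresponds to an expected step of a number no higher from compound 1 to compound 4 (the limit leaves the size open).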

Compound 4, half-maximal inhibitory concentration: > 10000 nM
Compound 4 ended at the assay's limit (the forecaster's own chance of this, stated with the estimate: 60%); the middle value lies on the limit itself.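

In this assay compound 4 gives > 10000 nM, a limit and not a number. Within the data shown here, compound 1 also sits at a limit, and no step between the two can be read. The compounds shown leave open whether 3-fluorophenyl in place of 4-methylphenyl changes activity at all.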